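Methoxy to Ethoxy on a Shared Core, Aorta Assay

The compounds below may be only part of what the source reports. "The series", "measured", "known", "first", "only" and "open" are said of these compounds alone.

Measured compounds:
compound 1 `CCOc1nc(-c2nc3ccccc3n2C)cc(-c2ccc(Cl)cc2Cl)c1C#N`, 305000 nM
compound 2 `COc1nc(-c2nc3ccccc3n2C)cc(-c2ccc(C)cc2)c1C#N`, 295000 nM

In a functional assay on aorta (Rattus norvegicus, strain Wister) (a higher number here means a weaker inhibitor, a lower number a stronger inhibitor), compound 1 gives 305000 nM. In this assay compound 2 gives 295000 nM, a number within the scatter of that of compound 1, so the two compounds stand alike. Compound 3 `CCOc1nc(-c2nc3ccccc3n2C)cc(-c2ccc(C)cc2)c1C#N` differs from compound 2 by methyl in place of hydrogen on a saturated chain carbon bound to an oxygen on an aromatic ring. Within the data shown here, no comparable step has been measured here, and on this ground no change beyond the scatter is expected: the step from compound 2 to compound 3 is estimated at a 1.1-fold lower number from compound 2 to compound 3 (0.02 log units; within the scatter). Compound 3 is therefore expected to give about 280000 nM, with a range from 120000 nM to 650000 nM.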

Compound 3, half-maximal inhibitory concentration: 400000 nM
The estimate for compound 3 lay 1.4-fold (0.15 log units) below the measured number; the measured number falls inside the stated range.
By their numbers in this assay, from the lowest: compounds 2, 1 and 3 (each within the scatter of the next).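

In this assay the change from methoxy to ethoxy gives a 1.4-fold higher number from compound 2 to compound 3 (0.13 log units; within the scatter) and stays within the scatter, so this first step at this position shows no change that can be told from repeat measurement. Likewise, 4-methylphenyl in place of 2,4-dichlorophenyl on an aromatic carbon gives a 1.3-fold higher number from compound 1 to compound 3 (0.12 log units; within the scatter) and also stays within the scatter. No evidence bears on these results.

From the compounds shown here alone, whether a longer chain, an amine or a carboxylic acid in place of the ethoxy would move the number beyond the scatter remains open.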